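The source may hold more compounds than are shown below. What is called first, only, known or untested is meant among the compounds shown, and "the series" means these compounds.

In an ADME assay (liver) for metabolic stability, with Liver microsome (Homo sapiens) as the target, read by LC-MS, using microsomes and NADPH, with a stated time of 5 min, at 37 degrees C (a lower number here means slower removal, a higher number faster removal of the compound), compound 1 (`CCn1c([C@@H](C)NS(=O)(=O)c2ccc(Cl)cc2)nc2ccccc21`) gives > 100 mL.min-1.g-1, which is a limit and not a number. Compound 2 (`CCn1c([C@@H](C)NS(=O)(=O)c2ccc(Cl)cc2)nc2ccc(OC)cc21`) gives > 100 mL.min-1.g-1, also a limit. Going by the values given here, the only measured evidence is the limit of > 100 mL.min-1.g-1 in this assay, at which 2 of the 2 values shown sit, and a step that the two limits leave unreadable from compound 1 to compound 2 sets no size for a change on this core. Compound 3 (`CCn1c([C@@H](C)NS(=O)(=O)c2ccc(Cl)cc2)nc2cc(C#N)ccc21`) differs from compound 1 by cyano in place of hydrogen on an aromatic carbon, with cyano in place of hydrogen on an aromatic carbon. With no readable step to guide it, removal is expected to remain fast, with no firm direction, and the expected step is an at least 1.2-fold lower number from compound 1 to compound 3 (0.09 log units; that floor lies within the scatter). Compound 3 is estimated at 80 mL.min-1.g-1, with an expected range from 30 mL.min-1.g-1 to 150 mL.min-1.g-1.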

Compound 3, intrinsic clearance in microsomes: 71 mL.min-1.g-1
The estimate for compound 3 lay 1.1-fold (0.05 log units) above the measured number, and the stated range covers the measured number.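

Cyano in place of hydrogen on an aromatic carbon gives the first readable step on the shared core in this assay: an at least 1.4-fold lower number from compound 1 to compound 3 (0.14 log units; that floor lies within the scatter). The step is only a floor, and the methoxy step cannot be read. The limit still holds the other compounds: the limit of > 100 mL.min-1.g-1 in this assay, at which 2 of the 3 values shown sit.

The compounds shown leave open how large the true step is. They also leave open whether an amine or a carboxylic acid on this aromatic carbon would give a lower number than the nitrile does.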